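This account rests on a few compounds, and the source may have more. Where it says the series, first, only, none or still open, it means among the compounds named here.

Compound 2, `ClCc1cccc(Cn2cnc3c(Cl)ncnc32)c1`, is one of two measured analogues built on a shared core carrying a chloromethyl-substituted benzyl group. In a functional assay on HCT-15 cells (Homo sapiens) for cytotoxicity, read by sulforhodamine B assay, with a stated time of 48 h (on this read-out higher numbers stand for weaker inhibition of growth and lower numbers for stronger inhibition of growth), compound 2 gives 4670 nM. Its only measured companion, compound 1, `ClCc1cccc(Cn2cnc3ncnc(Cl)c32)c1`, gives 4360 nM in this assay, a number that sits within the scatter of that of compound 2, so the two cannot be told apart. Compound 3, `ClCc1cccc(Cn2cnc3c(Cl)nc(Cl)nc32)c1`, has not yet been measured. It differs from compound 2 by chloro in place of hydrogen on an aromatic carbon. Among the measured compounds shown here, no measured pair shows what such a change does on this core, so there is no step to lean on. With nothing in the measured data pointing either way, the change is expected to leave the number close to where compound 2 stands, and the step is estimated at a 1.3-fold lower number from compound 2 to compound 3 (0.13 log units; within the scatter), not beyond the scatter. On that basis compound 3 is expected to give about 3500 nM in this assay, within a range from 1200 nM to 10000 nM.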

Compound 3, concentration for total growth inhibition: 6910 nM
For compound 3 the middle estimate is 2.0-fold (0.30 log units) below the measured one, within the range that was stated.
By their numbers in this assay, from the lowest: compounds 1, 2 and 3 (each within the scatter of the next).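

In this assay, placing chloro in place of hydrogen on the aromatic carbon between two ring nitrogen atoms gives a 1.5-fold higher number from compound 2 to compound 3 (0.17 log units; within the scatter) and so stays within the scatter. Among the compounds shown here, this carbon therefore carries a chloro group with no difference that this read-out can separate from repeat variation, something neither earlier compound could show, as they offered no pair differing in this way. No measurement shown here offers an explanation for this result.

A single step with one small group leaves open whether this position matters at all in this assay. An amine, a methoxy group or a longer chain on the same carbon could show whether larger or different groups there move the number beyond the scatter.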